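Methyl to ethyl on a shared core: an expected step

The compounds below may be only part of what the source reports. "The series", "measured", "known", "first", "only" and "open" are said of these compounds alone.

Measured so far:
compound 1, `S=c1[nH]nc(Cc2ccc(Cl)cc2Oc2ccccc2Cl)[nH]1`: 139% in a functional assay on the whole organism (strain NMRI) with Mus musculus as the target, with a stated time of 60 min, at a dose of 10 mg/kg by the intraperitoneal route; a higher number here means a stronger effect of the compound at the dose given, a lower number a weaker effect
compound 2, `CSc1nnc(Cc2ccc(Cl)cc2Oc2ccccc2Cl)[nH]1`: 132% in this assay

Compound 2 stands lowest of these two numbers, and compound 1 is its nearest neighbour. Among the compounds with values here, the only measured step, a number 7 percentage points lower from compound 1 to compound 2 (within the scatter), lies within the scatter, and it concerns the exchange of one five-membered aromatic ring with three hetero atoms for another, not the change considered here.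

Compound 3, `CCSc1nnc(Cc2ccc(Cl)cc2Oc2ccccc2Cl)[nH]1`, has not yet been measured in this assay. It differs from compound 2 by methyl in place of hydrogen on a saturated chain carbon bound to a sulfur. Within the data shown here, no measured step speaks to this methylsulfanyl-to-ethylsulfanyl change, so the expectation rests on the closeness of the two numbers already seen. Compound 3 is expected to give about 130% in this assay, with a range from 100% to 160%. The step this estimate means, a number 2 percentage points lower from compound 2 to compound 3 (within the scatter), is expected to stay within the scatter.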

Compound 3, a percentage reported as activity, at one dose (the size of the read-out at that dose, not a potency): 140%
Beside the measured number, compound 3's estimate is 10 percentage points below it; the measured number falls inside the stated range.
By their numbers in this assay, from the lowest: compounds 2, 1 and 3 (each within the scatter of the next).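

Within the data shown here, at the sulfur of the shared core, the change from methylsulfanyl to ethylsulfanyl gives the first reading for this position in this assay: a number 8 percentage points higher from compound 2 to compound 3 (within the scatter). Methyl in place of hydrogen on this saturated chain carbon bound to a sulfur therefore leaves the effect at the given dose within the usual scatter, and the same holds for the wider exchange that gives a number 1 percentage points higher from compound 1 to compound 3 (within the scatter), so all three compounds remain indistinguishable in this read-out. No measured information is available to explain these results.

The compounds shown do not tell how far the position tolerates change, since a longer chain such as propyl, or an amine or a carboxylic acid on that chain, does not appear among them. A read-out at one dose also leaves open how the size of the effect compares at other doses.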